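From hydroxy to vinyl on the 4-ethoxyphenyl compound

The compounds below may be only part of what the source reports. "The series", "measured", "known", "first", "only" and "open" are said of these compounds alone.

In a functional assay on MCF7 cells (Homo sapiens) for inhibition, read by resazurin assay, with a stated time of 72 h (on this read-out lower numbers stand for stronger inhibition and higher numbers for weaker inhibition), compound 3 (`CCOc1ccc(C2C(O)C(=O)N2c2cc(OC)c(OC)c(OC)c2)cc1`) gives 7 nM and holds the lowest number of the three measured compounds. Compound 1 (`C=CC1C(=O)N(c2cc(OC)c(OC)c(OC)c2)C1c1ccc(SC)cc1`) gives 51 nM and compound 2 (`C=CC1C(=O)N(c2cc(OC)c(OC)c(OC)c2)C1c1ccc(SCC)cc1`) gives 181 nM with vinyl on the saturated ring carbon.

Compound 4 (`C=CC1C(=O)N(c2cc(OC)c(OC)c(OC)c2)C1c1ccc(OCC)cc1`) keeps the 4-ethoxyphenyl group of compound 3 and carries vinyl in place of hydroxy on a saturated ring carbon. Among the measured compounds shown here, no measured step makes this swap. For the measured compounds named here, the only single-site step is a 3.5-fold higher number from compound 1 to compound 2 (0.55 log units; beyond the scatter) on the sulfur-bound chain and not at this carbon, so it bears only indirectly and shows that a one-carbon difference elsewhere can move the number modestly. Compound 1 at 51 nM is the nearest vinyl-bearing value, and it points towards a higher number for compound 4.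

The expected change in this assay is a 3.6-fold higher number from compound 3 to compound 4 (0.55 log units; beyond the scatter) and thus weaker inhibition, though this rests on little data. Compound 4 is estimated at 25 nM with an expected range from 7 nM to 90 nM for the measurement.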

Compound 4, half-maximal inhibitory concentration: 14 nM
Compound 4: the middle estimate sits 1.8-fold (0.25 log units) above what was measured, and the stated range covers the measured number.
By their numbers in this assay, from the lowest: compounds 3 and 4 (each within the scatter of the next); then compound 1; then compound 2.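

In this assay, among the compounds shown here, the first direct reading at this saturated ring carbon is a 2.0-fold higher number from compound 3 to compound 4 (0.30 log units; within the scatter), so hydroxy and vinyl cannot be told apart here on the 4-ethoxyphenyl compounds. With vinyl held in place, the larger movement lies on the aromatic carbon: a 13-fold lower number from compound 2 to compound 4 (1.11 log units; beyond the scatter) and a 3.6-fold lower number from compound 1 to compound 4 (0.56 log units; beyond the scatter). Both of these steps lie beyond the scatter, and in this set of compounds ethoxy gives the lower number against both sulfur-bound groups.

The compounds shown leave open whether an amine or a longer chain on this ring carbon would also stay within the scatter of hydroxy and vinyl, and whether the same holds with methylsulfanyl or ethylsulfanyl on the aromatic carbon. Nothing available explains why either swap gives the step it does.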